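An iodo group added to compound 2

The source may report more compounds than this note shows. Statements on the series, on what has been measured and on what is new or still open speak of the compounds shown alone.

In a functional assay on MCF7 cells (Homo sapiens) for antiproliferative activity, read by sulforhodamine B assay, with a stated time of 72 h (a higher number here means a weaker inhibitor, a lower number a stronger inhibitor), compound 1 (`COc1ccc(/C=C2\CCC=CC2=O)cc1OC`) gives 5230 nM and compound 2 (`COc1cc(/C=C2\CCC=CC2=O)cc(OC)c1OC`) gives 5260 nM so these two stand level. Compound 3 (`COc1cc(/C=C2\CCC=C(I)C2=O)cc(OC)c1OC`) carries iodo in place of hydrogen on a double-bonded ring carbon. For the measured compounds named here, the only measured step (a 1.0-fold higher number from compound 1 to compound 2 (0.00 log units; within the scatter)) is methoxy in place of hydrogen on an aromatic carbon, and it lies within the scatter. It is a different change in a different place, so it gives no direction for iodo, and no step beyond the scatter is expected in this assay. The expected result is a 1.2-fold lower number from compound 2 to compound 3 (0.07 log units; within the scatter). Compound 3 is estimated at 4500 nM within a wide range of 1000 nM to 15000 nM.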

Compound 3, half-maximal inhibitory concentration: 5330 nM
Compound 3: the middle estimate sits 1.2-fold (0.07 log units) below what was measured; measured number inside the range.
By their numbers in this assay, from the lowest: compounds 1, 2 and 3 (each within the scatter of the next).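

Within this assay iodo in place of hydrogen on a double-bonded ring carbon gives a 1.0-fold higher number from compound 2 to compound 3 (0.01 log units; within the scatter) and leaves compound 2 and compound 3 level. For the compounds shown here, the earlier compounds differed only on the aromatic ring, so this is the first sign that the six-membered non-aromatic ring can carry an iodine atom while the number stays within the scatter. No supporting measurement is available to explain this result. Still open, from the compounds shown here alone, is whether an amine or a carboxylic acid on this same carbon would give a different number. Iodo on compound 1 also remains an open case.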